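From Hydroxy to Chloro: Estimating One Cytotoxicity Step

A few compounds are considered here, and "the series" means these few. Any claim that something is new, unique, unknown or untested is made for them only; others in the source may bear on it.

Measured in a functional assay on A549 cells (Homo sapiens) for cytotoxicity; on this read-out higher numbers stand for an effect only at larger amounts of compound and lower numbers for an effect already at smaller amounts:
Compound 1 `CCOc1cc(-c2ccccc2)nc2ccccc12`: > 10 ug/mL (a limit)
Compound 2 `c1ccc(COc2cc(-c3ccccc3)nc3ccccc23)cc1`: > 10 ug/mL (a limit)
Compound 3 `Oc1ccc2nc(-c3ccccc3)cc(O)c2c1`: 8.14 ug/mL

Going by the values given here, compound 3 gives 8.14 ug/mL in this assay, and this is the only true number among the three results. The other two results are limits, so compound 3 cannot be placed in a firm order against them.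

Compound 4 `Oc1cc(-c2ccccc2)nc2ccc(Cl)cc12` has not yet been measured. It differs from compound 3 by one change (chloro in place of hydroxy on an aromatic carbon), with chloro in place of hydroxy on an aromatic carbon.

Among the compounds with values here, the only measured step offers little guidance. It is a step that the two limits leave unreadable from compound 1 to compound 2, and it concerns a different change, so it gives no size to carry over. Within the data shown here, with no measured hydroxy-to-chloro step to draw on, no step beyond the usual scatter is expected, in either direction. The expected step is a 1.1-fold higher number from compound 3 to compound 4 (0.04 log units; within the scatter).

Compound 1 and compound 2 share (the limit of > 10 ug/mL in this assay, at which 2 of the 3 values shown sit). A limit rather than a number is therefore also a real possibility for compound 4.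

For compound 4 the estimated value is 9 ug/mL, with an expected range from 3.5 ug/mL to 20 ug/mL.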

Compound 4, half-maximal effective concentration: 0.51 ug/mL
For compound 4 the middle estimate is 18-fold (1.25 log units) above the measured one; measured number outside the range, below it.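

The exchange at this one place on the carbon-only six-membered aromatic ring is small on paper, with one heavy atom leaving and one entering, yet in this assay it gives a 16-fold lower number from compound 3 to compound 4 (1.20 log units; beyond the scatter). Going by these compounds alone, this is the first readable step, and it shows that the group at this place matters to the read-out: compound 4 produces its effect at much smaller amounts than compound 3. Compound 4 also gives a true number rather than joining the limit held by compound 1 and compound 2: the limit of > 10 ug/mL in this assay, at which 2 of the 4 values shown sit.

The count of hydrogen-bond donors and acceptors falls with this change, but a single pair of compounds cannot tell whether the step comes from losing the hydroxy, gaining the chloro, or both, and it offers no measured property to explain the size of the step. Among the compounds shown, nothing tells how a bromo, a methoxy or an amine at this same place would compare in this assay, so it remains open whether the large step is particular to chloro or extends to other groups.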